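The source may report more compounds than this note shows. Statements on the series, on what has been measured and on what is new or still open speak of the compounds shown alone.

Measured in a functional assay on A549 cells (Homo sapiens) for antiproliferative activity, read by MTT assay, with a stated time of 72 h; on this read-out lower numbers stand for stronger inhibition and higher numbers for weaker inhibition:
Compound 1 `COc1ccc(N2C(=O)COc3ccc(-c4ccc(O)cc4)cc32)cc1`: > 40000 nM
Compound 2 `COc1cccc(N2C(=O)COc3ccc(-c4cccc(NS(=O)(=O)c5ccc(F)cc5)c4)cc32)c1`: > 40000 nM

Neither entry is a number. In this assay compound 1 gives > 40000 nM, which is a limit of the assay. Compound 2 gives > 40000 nM, which is likewise a limit. For the measured compounds named here, the evidence so far is the limit of > 40000 nM in this assay, at which 2 of the 2 values shown sit, so compound 1 has no measured step to any neighbour.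

Compound 3 `COc1cccc(N2C(=O)COc3ccc(-c4ccc(O)cc4)cc32)c1` has the same atoms as compound 1, joined differently: 3-methoxyphenyl in place of 4-methoxyphenyl on an amide-type nitrogen in a ring. Compound 2 already carries 3-methoxyphenyl, and its > 40000 nM is also a limit. A small change is therefore expected in this assay, towards stronger inhibition if there is any, and the reading may well stay at the limit. The estimated step is an at least 1.6-fold lower number from compound 1 to compound 3 (0.20 log units; that floor lies within the scatter). For compound 3 the expected value is 25000 nM, with an estimated range of 5000 nM to 40000 nM.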

Compound 3, half-maximal inhibitory concentration: > 40000 nM
Compound 3: no number, only a limit (the forecaster's own chance of this, stated with the estimate: 55%); middle value at least 1.6-fold (0.20 log units) away from the limit.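

No step can be read between compound 1 and compound 3 in this assay, as both entries are limits and not numbers: the limit of > 40000 nM in this assay, at which 3 of the 3 values shown sit.

The compounds shown leave open whether 3-methoxyphenyl in place of 4-methoxyphenyl changes inhibition at all, and what any compound's actual value is.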